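The source may hold more compounds than are shown below. What is called first, only, known or untested is meant among the compounds shown, and "the series" means these compounds.

Measured so far:
compound 1 `Cn1cncc1CN1CC(N(CC2CCN(C(=O)C(C)(C)C)CC2)S(=O)(=O)c2ccccn2)Cc2cc(C#N)ccc21` gives 0.5 10^-6 cm/s
compound 2 `Cn1cncc1CN1CC(N(CC2CCN(C(=O)CC(F)(F)F)CC2)S(=O)(=O)c2ccccn2)Cc2cc(C#N)ccc21` gives 0.5 10^-6 cm/s
compound 3 `CC(C)S(=O)(=O)N1CCC(CN(C2Cc3cc(C#N)ccc3N(Cc3cncn3C)C2)S(=O)(=O)c2ccccn2)CC1` gives 0.1 10^-6 cm/s

The read-out in every case is an ADME assay on Caco-2 cells (Homo sapiens) for permeability, in the apical to basolateral direction; a lower number here means that the compound crosses the layer more slowly, a higher number that the compound crosses the layer faster. Compound 1 stands level with compound 2, and together they hold the highest numbers of the three. The step of no change at the digits printed from compound 1 to compound 2 (within the scatter) stays within the scatter, while a 5.0-fold lower number from compound 1 to compound 3 (0.70 log units; beyond the scatter) is a modest fall beyond it, and a 5.0-fold lower number from compound 2 to compound 3 (0.70 log units; beyond the scatter) repeats that fall from the other starting point.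

Compound 4 `C=C(C)C(=O)N1CCC(CN(C2Cc3cc(C#N)ccc3N(Cc3cncn3C)C2)S(=O)(=O)c2ccccn2)CC1` is compound 1 with one change: 1-methylethenyl in place of tert-butyl on a carbonyl carbon. Within the data shown here, of the three measured steps, the one from compound 1 to compound 2 is the closest parallel, since there too the group sitting on the carbonyl carbon was exchanged while the carbonyl itself and the amide-type nitrogen in the ring were kept, and the number did not move beyond the scatter. The two steps leading to compound 3 are of a different kind, since they replace the whole carbonyl group by a sulfonyl, so they say little about the present exchange.

On that basis compound 4 is expected to sit close to compound 1, with an estimated step of a 1.3-fold lower number from compound 1 to compound 4 (0.10 log units; within the scatter), and no change beyond the scatter is expected. The estimate for compound 4 is 0.4 10^-6 cm/s, expected to fall between 0.15 10^-6 cm/s and 1.2 10^-6 cm/s.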

Compound 4, apparent permeability: 0.5 10^-6 cm/s
Compound 4: the middle estimate sits 1.3-fold (0.10 log units) below what was measured, and the stated range covers the measured number.
By their numbers in this assay, from the lowest: compound 3; then compounds 1, 2 and 4 (each within the scatter of the next).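

In this assay, 1-methylethenyl on the carbonyl carbon reads the same as tert-butyl (no change at the digits printed from compound 1 to compound 4 (within the scatter)) and the same as 2,2,2-trifluoroethyl (no change at the digits printed from compound 2 to compound 4 (within the scatter)), so a third group, with 3 heavy atoms and a double bond outside aromatic rings, joins the two already level at this position. The gap to the sulfonyl compound also appears from this new starting point (a 5.0-fold higher number from compound 3 to compound 4 (0.70 log units; beyond the scatter)), so among these four compounds, the three with a carbonyl on the ring nitrogen read alike and the one with isopropylsulfonyl, compound 3, stands apart with no exception. No measurement shown here explains either observation.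

As far as these compounds go, all three groups on the carbonyl carbon are built only from carbon, with fluorine in one case, so it remains open whether an amine, a carboxylic acid or a longer alkyl chain at this place would leave the number level or move it beyond the scatter. From the compounds shown here alone, it is also open whether the gap between carbonyl and sulfonyl holds for sulfonyl groups other than isopropylsulfonyl, such as methylsulfonyl or phenylsulfonyl, on the same ring nitrogen.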